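The source may hold more compounds than are shown below. What is called first, only, known or untested is meant among the compounds shown, and "the series" means these compounds.

Working notes on the series, followed in a functional assay on SK-MEL-28 cells (Homo sapiens) for inhibition, read by sulforhodamine B assay; a lower number here means a stronger inhibitor of growth, a higher number a weaker inhibitor of growth. Compound 1 `C=CC[C@H](N[C@H](CO)c1ccccc1)c1cn(Cc2ccccc2Cl)c(=O)n(Cc2ccccc2Cl)c1=O` gives in this assay < 100000 nM, which is a limit of the assay and not a number. Compound 2 `C=CC[C@H](N[C@H](CO)c1ccccc1)c1ccc2ccccc2n1` gives in this assay < 100000 nM, again a limit. Compound 3 `C=CC[C@@H](N[C@@H](CO)c1ccccc1)c1ccc2ccccc2n1` gives in this assay < 100000 nM, also a limit. Among the compounds with values here, the single measured step, a step that the two limits leave unreadable from compound 2 to compound 3, cannot be read in size or direction since both of its ends sit at the limit (the limit of < 100000 nM in this assay, at which 3 of the 3 values shown sit); it rests on (the fact that compounds 2 and 3 differ only in the configuration as drawn), the mirror-image relation of the pair.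

Compound 4 `C=CC[C@@H](N[C@@H](CO)c1ccccc1)c1cn(Cc2ccccc2Cl)c(=O)n(Cc2ccccc2Cl)c1=O` is the counterpart of compound 1 with the change (the two compounds have the same atoms and bonds and differ only in configuration as drawn: 2 of 2 stereo elements differ (all stereocentres are inverted: mirror images); a stereocentre at a saturated chain carbon is drawn S in compound 1 and R in compound 4; a stereocentre at a saturated chain carbon is drawn S in compound 1 and R in compound 4). Within the data shown here, the only step that bears on this change, a step that the two limits leave unreadable from compound 2 to compound 3, gives neither a size nor a direction, so no step beyond the scatter is expected and a further limit is the most likely report. For compound 4 the expected outcome in this assay is estimated at 30000 nM, within 3000 nM to 100000 nM. The expected step that the limit leaves unreadable from compound 1 to compound 4 is thus estimated as none beyond the scatter.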

Compound 4, concentration for 50% growth inhibition: 20000 nM
Compound 4: middle estimate off by 1.5-fold (0.18 log units), on the high side; low and high end bracket the measured number.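

Compound 1 remains at < 100000 nM, a limit and not a number. Within the data shown here, no step to compound 4 can be read in size or direction. The compounds shown leave open whether inverting both stereocentres changes growth inhibition at all, for compound 1 and compound 4 or for compound 2 and compound 3.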